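A few compounds are considered here, and "the series" means these few. Any claim that something is new, unique, unknown or untested is made for them only; others in the source may bear on it.

The measured compounds, each with its result:
Compound 1, `CC(Oc1ccccc1Br)C1=NCCN1`, gives 316 nM in a functional assay on CHO cells for agonist activity at Alpha-2B adrenergic receptor (Homo sapiens); a lower number here means that less compound is needed, a higher number that more compound is needed for the effect.
Compound 2, `C=COc1ccccc1OC(C)C1=NCCN1`, gives 3160 nM in this assay.

Of these two numbers, compound 1 stands lowest; its nearest neighbour is compound 2, reached by a 10-fold higher number from compound 1 to compound 2 (1.00 log units; beyond the scatter), a step that exchanged vinyloxy in place of bromo on an aromatic carbon and lay clearly beyond the scatter. Compound 3, `CC(=O)c1ccccc1OC(C)C1=NCCN1`, is the next compound to be tested in this assay. It differs from compound 1 as follows: acetyl in place of bromo on an aromatic carbon. For the measured compounds named here, only one measured step bears on this change, namely a 10-fold higher number from compound 1 to compound 2 (1.00 log units; beyond the scatter), in which bromo likewise gave way to another group at the same aromatic carbon. Since acetyl also displaces bromo there, compound 3 is expected to move in the same direction, by a step estimated at a 4.7-fold higher number from compound 1 to compound 3 (0.68 log units; beyond the scatter), though a smaller or larger shift cannot be excluded on one precedent. Compound 3 is accordingly estimated at 1500 nM, with a range from 400 nM to 6000 nM.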

Compound 3, half-maximal effective concentration: 295 nM
Compound 3: the middle estimate sits 5.1-fold (0.71 log units) above what was measured, outside the stated range (below it).
By their numbers in this assay, from the lowest: compounds 3 and 1 (each within the scatter of the next); then compound 2.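

Acetyl at this aromatic carbon shows that the loss seen with vinyloxy does not follow from removing bromo alone: in this assay the exchange gives a 1.1-fold lower number from compound 1 to compound 3 (0.03 log units; within the scatter) and stays within the scatter. Against vinyloxy, the same acetyl group gives an 11-fold lower number from compound 2 to compound 3 (1.03 log units; beyond the scatter) and so places compound 2 apart from compound 1 and compound 3, with the difference lying beyond the scatter. Nothing at hand explains why acetyl and bromo read alike here while vinyloxy does not.

The three compounds leave open how other groups at this carbon would read, such as an amine, a carboxylic acid or a longer acyl chain. They also leave open whether any group here can give a clearly lower number than bromo and acetyl do.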